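The source may report more compounds than this note shows. Statements on the series, on what has been measured and on what is new or still open speak of the compounds shown alone.

In a functional assay on PC-3 cells (Homo sapiens) for antiproliferative activity, read by MTT assay, with a stated time of 72 h (a higher number here means a weaker inhibitor, a lower number a stronger inhibitor), compound 1 `CCn1c(C(=O)NCc2ccc(OC)cc2)ccc1C(CC)(CC)c1ccc(C#CC(O)(CC)CC)c(C)c1` gives > 50000 nM, and that value is a limit of the assay, not a number. Among the compounds with values here, compound 2 `CCn1cc(C(CC)(CC)c2ccc(C#CC(O)(CC)CC)c(C)c2)cc1C(=O)NCCN(C)C` gives 10100 nM, which makes it the only compound so far with an actual number, so it cannot yet be ranked against a second measured value.

Compound 3 `CCn1cc(C(CC)(CC)c2ccc(C#CC(O)(CC)CC)c(C)c2)cc1C(=O)N[C@@H](C)CO` keeps the core of compound 2 and differs only in the group on the amide. The change is 1-(hydroxymethyl)ethyl in place of 2-(dimethylamino)ethyl on an amide-type nitrogen.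

Within the data shown here, no measured pair isolates a change at this place, so any expectation for its size in this assay remains loose. A moderate move toward weaker inhibition is expected, starting from compound 2 at 10100 nM, though a result within the usual scatter would not be surprising. The estimated change is a 2.0-fold higher number from compound 2 to compound 3 (0.30 log units; within the scatter). Compound 3 is expected to give about 20000 nM, with an estimated range of 7000 nM to 50000 nM.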

Compound 3, half-maximal inhibitory concentration: 6050 nM
Compound 3: the middle estimate sits 3.3-fold (0.52 log units) above what was measured; measured number below the stated range.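

In this assay, within the data shown here, the change at the amide-type nitrogen can now be read for the first time, and it gives a 1.7-fold lower number from compound 2 to compound 3 (0.22 log units; within the scatter). This position therefore accepts 1-(hydroxymethyl)ethyl in place of 2-(dimethylamino)ethyl with no step beyond the scatter, even though the entering group carries a hydrogen-bond donor and a defined stereocentre that the leaving group lacks, and the basic dimethylamino end of the chain is gone from the compound only in name of structure, not as any measured effect. Nothing measured here bears on why this step has the size it has.

Compound 1, at > 50000 nM, a limit of the assay and not a number, differs from the other compounds in more than one place and so says nothing about this position. On these data alone, whether a carboxylic acid, a primary amine or a longer chain on the same amide-type nitrogen would move the number beyond the scatter stays open, as does the effect of the opposite configuration at the new stereocentre.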